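The source may hold more compounds than are shown below. What is called first, only, known or untested is meant among the compounds shown, and "the series" means these compounds.

Among the measured compounds shown here, compound 1 `Cc1cccc(OCc2nc3c(c(=O)n(C)c(=O)n3C)n2C)c1` is the only member of the series with a number in an in vitro assay on cells for inhibition of Amine oxidase [flavin-containing] A (Homo sapiens), read by coupled enzyme assay, with a stated time of 20 min; a lower number here means a stronger inhibitor, a higher number a weaker inhibitor: compound 1 gives 18800 nM, a weak result. Compound 2 `Cn1c(=O)c2c(nc(COc3cccc(Cl)c3)n2C)n(C)c1=O` is recorded in this assay as "not active" (no number reported), with no concentration reported. Compound 2 therefore stands without a single number; all that is known is that it showed no measurable inhibition under the conditions used. Compound 3 `Cn1c(=O)c2c(nc(COc3ccc(Br)cc3)n2C)n(C)c1=O` has not been tested in this assay. Compound 3 differs from compound 2 by 4-bromophenyl in place of 3-chlorophenyl on an oxygen on a saturated carbon. For the measured compounds named here, no step between two measured compounds is available to size this exchange. Given the record of compound 2 at "not active" (no number reported) and the weak figure of compound 1 at 18800 nM, no change beyond the scatter is expected, and compound 3 is expected to remain weak or to return no number. Compound 3 is estimated at 40000 nM in this assay, with a range from 10000 nM to 200000 nM.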

Compound 3, half-maximal inhibitory concentration: 10700 nM
Compound 3: middle estimate off by 3.7-fold (0.57 log units), on the high side; the range from low to high includes it.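

In this assay, the exchange at this position, on an oxygen on a saturated carbon, gives a 1.8-fold lower number from compound 1 to compound 3 (0.24 log units; within the scatter) for 4-bromophenyl in place of 3-methylphenyl, so these two groups are not told apart by this read-out. The step between compound 2 and compound 3 cannot be read, as compound 2 has no number, but compound 3 shows that a measurable reading here is not confined to 3-methylphenyl. Nothing measured bears on the difference in outcome between 3-chlorophenyl and the other two groups.

Still open, from the compounds shown here alone, is whether an amine, a carboxylic acid or a longer chain in place of the aromatic ring would move the number beyond the scatter. Compound 2 and compound 3 differ in both the halogen and its place on the ring, so the contribution of each remains unresolved.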